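Swapping the sulfonamide amine in a macrocyclic acylsulfonamide

The source may hold more compounds than are shown below. What is called first, only, known or untested is meant among the compounds shown, and "the series" means these compounds.

Measured so far:
compound 1, `COc1ccc2c(OCC[C@@H]3NC(=O)N(C)CCCC/C=C\[C@@H]4C[C@@]4(C(=O)NS(=O)(=O)N(C)C)NC3=O)cc(-c3nc(C(C)C)cs3)nc2c1Cl`, 47800 nM
compound 2, `COc1ccc2c(OCC[C@@H]3NC(=O)N(C)CCCC/C=C\[C@@H]4C[C@@]4(C(=O)NS(=O)(=O)C4(C)CC4)NC3=O)cc(-n3ccc(C(C)C)n3)nc2c1C`, 25600 nM

Both measured compounds were tested in an ADME assay on cells (Homo sapiens) for activation; a lower number here means that less compound is tolerated, a higher number that more compound is tolerated. Compound 1 gives 47800 nM and compound 2 gives 25600 nM; the two numbers lie close enough together that the difference between them falls within the usual scatter of this kind of measurement, so neither can be called the better tolerated of the pair.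

Compound 3, `COc1ccc2c(OCC[C@@H]3NC(=O)N(C)CCCC/C=C\[C@@H]4C[C@@]4(C(=O)NS(=O)(=O)N4CCOCC4)NC3=O)cc(-c3nc(C(C)C)cs3)nc2c1Cl`, has not been measured yet. It differs from compound 1 in a single spot: morpholin-4-yl in place of dimethylamino on a sulfonyl sulfur. The two compounds share everything else, including the macrocyclic core and the chloro-substituted quinoline bearing the thiazole.

Going by the values given here, no pair of measured compounds differs in just one place, so there is no measured step to lean on. The change is small and the two measured values suggest that this series tolerates variation at the periphery without a large shift. The step from compound 1 to compound 3 is therefore expected to be a 1.1-fold lower number from compound 1 to compound 3 (0.03 log units; within the scatter), that is, no change beyond the scatter in either direction. Compound 3 is estimated at 45000 nM, within a range of 20000 nM to 95000 nM in this assay.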

Compound 3, half-maximal cytotoxic concentration: 26400 nM
For compound 3 the middle estimate is 1.7-fold (0.23 log units) above the measured one; measured number inside the range.
By their numbers in this assay, from the lowest: compounds 2, 3 and 1 (each within the scatter of the next).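

Going by these compounds alone, compound 3 gives the first direct reading at this position, on a sulfonyl sulfur whose other neighbour is an amide-type nitrogen. In this assay, putting morpholin-4-yl in place of dimethylamino gives a 1.8-fold lower number from compound 1 to compound 3 (0.26 log units; within the scatter), so the two compounds cannot be told apart in this measurement. This pair therefore shows that a larger group, with a six-membered non-aromatic ring and one hydrogen-bond acceptor, can take the place of dimethylamino without a change that stands clear of the scatter, although nothing available here explains this result.

This single exchange does not show how far that tolerance extends, for instance to piperazin-1-yl, which brings a further ring nitrogen, or to diethylamino, which has longer chains but no ring. Within the data shown here, it also remains open whether morpholin-4-yl and dimethylamino would again read alike on a core other than that of compound 1, since only this one matched pair is available.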